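The compounds below may be only part of what the source reports. "The series", "measured", "known", "first", "only" and "open" are said of these compounds alone.

Working notes on the series. Compound 1 `COc1ccc(OC)c(CN(C(=O)Nc2ccc(C)cc2)n2cnnc2)c1` and compound 2 `O=C(NCc1ccccc1)N(Cc1ccccn1)n1cnnc1` share the core and have both been run in a functional assay on MCF7 cells (Homo sapiens) for cytotoxicity, read by MTT assay, with a stated time of 48 h; on this read-out lower numbers stand for stronger inhibition and higher numbers for weaker inhibition. In this assay compound 1 returns only a limit, > 50000 nM. In this assay compound 2 likewise returns only a limit, > 50000 nM, so where compound 2 stands is known only as a limit, not as a number. Across the pair the picture is the limit of > 50000 nM in this assay, at which 2 of the 2 values shown sit, and no measured step between two numbers exists to set a scale. Compound 3 `CC1CCC(NC(=O)N(Cc2ccccn2)n2cnnc2)CC1` has not been measured; against compound 2 the change is 4-methylcyclohexyl in place of benzyl on an amide-type nitrogen. With both shown values sitting at the limit, no direction can be read from the series, and the expectation for compound 3 is that this assay again reports a limit rather than a number. For compound 3 the estimate in this assay is 60000 nM, range 20000 nM to 200000 nM. The step this implies, a step that the limit leaves unreadable from compound 2 to compound 3, is expected to lie within the scatter.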

Compound 3, half-maximal inhibitory concentration: 34000 nM
For compound 3 the middle estimate is 1.8-fold (0.25 log units) above the measured one; measured number inside the range.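

Going by these compounds alone, compound 3 is the first compound to give a number in this assay, 34000 nM. This shows that a value below the limit can be reached with 4-methylcyclohexyl in place of benzyl on this amide-type nitrogen. The change gives an at least 1.4-fold lower number from compound 2 to compound 3 (0.16 log units; that floor lies within the scatter); only a floor is known, so the true size of the step cannot be read and may or may not exceed the scatter. One number sets no scale for the series, whose other values remain limits: the limit of > 50000 nM in this assay, at which 2 of the 3 values shown sit.

Whether the non-aromatic ring or its methyl is what matters stays open, as plain cyclohexyl does not stand among the compounds shown. The compounds shown also leave open how an amine, a carboxylic acid or a longer alkyl chain would read on this nitrogen.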